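The compounds below may be only part of what the source reports. "The series", "measured", "known", "first", "only" and "open" are said of these compounds alone.

In a functional assay on LOX IMVI cells (Homo sapiens) for antiproliferative activity, read by sulforhodamine B assay, with a stated time of 48 h (on this read-out higher numbers stand for weaker inhibition and lower numbers for stronger inhibition), three compounds have been measured:

Compound 1 `Nc1cccc2c(-c3cccc(NC(=O)c4ccc(Cl)c(C(F)(F)F)c4)c3)ccnc12` gives 3200 nM.
Compound 2 `CC(=O)Nc1cccc2c(-c3cccc(NC(=O)c4ccc5c(c4)OCCO5)c3)ccnc12` gives 96 nM.
Compound 3 `Nc1cccc2c(-c3cccc(NC(=O)Nc4cc(C(F)(F)F)cc(C(F)(F)F)c4)c3)ccnc12` gives 1500 nM.

Compound 3 holds the second highest number of the three in this assay. Its nearest neighbour is compound 1, whose number is higher by a margin beyond the scatter, while compound 2 lies far below it, a gap that is also well beyond the scatter. Among the measured compounds shown here, compound 2 is the only one of the three whose core nitrogen carries an acetyl group, and it is also the one with the lowest number; compound 1 and compound 3, with the free amino group, sit at the high end. For the measured compounds named here, the amide or urea portions differ among the three, so no single pair isolates the acetyl change.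

Compound 4 `CC(=O)Nc1cccc2c(-c3cccc(NC(=O)Nc4cc(C(F)(F)F)cc(C(F)(F)F)c4)c3)ccnc12` is the acetylated counterpart of compound 3. The change is acetyl in place of hydrogen on a nitrogen on an aromatic ring. Since compound 2 gives 96 nM and compound 3 gives 1500 nM, the author expects the acetyl to lower the number, and estimates a step of a 3.8-fold lower number from compound 3 to compound 4 (0.57 log units; beyond the scatter) in this assay, well beyond the scatter. For compound 4 the author therefore estimates 400 nM in this assay, with a range from 80 nM to 2000 nM.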

Compound 4, half-maximal inhibitory concentration: 19100 nM
For compound 4 the middle estimate is 48-fold (1.68 log units) below the measured one; the measured number lies above the stated range.
By their numbers in this assay, from the lowest: compound 2; then compound 3; then compound 1; then compound 4.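

In this assay, among the compounds shown here, compounds 3 and 4 form the first pair that differs in one place, and they give a direct reading of this nitrogen on an aromatic ring: going from amino to acetamido brings a 13-fold higher number from compound 3 to compound 4 (1.10 log units; beyond the scatter), a large step towards weaker inhibition. The earlier link between the acetyl and a low number therefore does not hold for this pair, since compound 2 gives 96 nM while compound 4, with the same acetamido group and a urea in place of the amide, gives 19100 nM, so the acetyl alone cannot account for the low number of compound 2. Nothing shown here bears on why this step goes in this direction or reaches this size.

For the compounds shown here, what the same change does when an amide rather than a urea is present stays open, as this single pair is the only reading of it. Also open, on these data alone, is how a formyl group, a propionyl group or a methyl group on this nitrogen would compare with the hydrogen and the acetyl.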